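A few compounds are considered here, and "the series" means these few. Any claim that something is new, unique, unknown or untested is made for them only; others in the source may bear on it.

In an ADME assay on the whole organism (plasma) for pharmacokinetics, with Rhesus monkey (Macaca mulatta) as the target, read by LC-MS, at a dose of 1 mg/kg by the oral route (on this read-out higher numbers stand for higher exposure at the dose given and lower numbers for lower exposure), compound 1 `COc1ccc2nc(COc3ccc(CC(SC)C(N)=O)cc3)n(C)c2c1` gives 16.9 ng.h/mL, the lowest of the three numbers recorded. Compound 2 `Cn1c(COc2ccc(CC3SC(=O)NC3=O)cc2)nc2ccc(O)cc21` gives 310 ng.h/mL in this assay, and compound 3 `COc1ccc2nc(COc3ccc(CC4SC(=O)NC4=O)cc3)[nH]c2c1` gives 2300 ng.h/mL; both stand beyond the scatter above compound 1. Compound 4 `COc1ccc2nc(COc3ccc(CC4(O)SC(=O)NC4=O)cc3)n(C)c2c1` has not yet been measured. It differs from compound 1 in one place: 5-hydroxy-2,4-dioxo-1,3-thiazolidin-5-yl in place of carbamoyl(methylsulfanyl)methyl on a saturated chain carbon bound to an aromatic carbon. Going by the values given here, no step between measured compounds that differ in a single place is available, so the expectation rests on the spread of the three numbers, in which compound 2 at 310 ng.h/mL and compound 3 at 2300 ng.h/mL sit far above compound 1. The step expected in this assay is a 12-fold higher number from compound 1 to compound 4 (1.07 log units; beyond the scatter), upward and beyond the scatter. Compound 4 is estimated at 200 ng.h/mL, within 40 ng.h/mL to 1000 ng.h/mL.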

Compound 4, area under the concentration-time curve: 7.33 ng.h/mL
Estimate against measurement, compound 4: 27-fold (1.44 log units) above; the measured number lies below the stated range.
By their numbers in this assay, from the lowest: compound 4; then compound 1; then compound 2; then compound 3.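

In this assay, 5-hydroxy-2,4-dioxo-1,3-thiazolidin-5-yl in place of carbamoyl(methylsulfanyl)methyl on a saturated chain carbon bound to an aromatic carbon gives a 2.3-fold lower number from compound 1 to compound 4 (0.36 log units; beyond the scatter). Going by these compounds alone, this is the first single-place step at this position, and it shows that this ring does not raise the number on the core of compound 1. Nothing available explains the fall. The compounds shown leave open how a carboxylic acid or an amine would read at this place, and what the hydroxy group on the ring contributes on its own.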